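Stability notes on the bicyclic carboxylic acid series

This account rests on a few compounds, and the source may have more. Where it says the series, first, only, none or still open, it means among the compounds named here.

Compound 1 `C[C@@H](O)[C@H]1C(=O)N2C(C(=O)O)=C(C(C)(C)C)O[C@H]12` gives 8.1 h in an ADME assay, in phosphate buffer, at 28 degrees C, at pH 7.0 (a lower number here means that the compound disappears faster, a higher number that the compound lasts longer), the highest number among the three measured analogues, though both neighbours sit within the scatter. Compound 2 `CC(C)(C)C1=C(C(=O)O)N2C(=O)[C@H]([C@H](O)c3ccccc3)[C@H]2O1` gives 7 h and compound 3 `Cn1cc([C@@H](O)[C@H]2C(=O)N3C(C(=O)O)=C(C(C)(C)C)O[C@H]23)nn1` gives 6.8 h; the steps of a 1.2-fold lower number from compound 1 to compound 2 (0.06 log units; within the scatter) and a 1.2-fold lower number from compound 1 to compound 3 (0.08 log units; within the scatter) are flat. Compound 4 `CC(=O)NC[C@H]1C(=O)N2C(C(=O)O)=C(C(C)(C)C)O[C@H]12` carries a different change: acetamidomethyl in place of 1-hydroxyethyl on a saturated ring carbon. For the measured compounds named here, no measured step touches this part of the side chain, so the only guide is that every variation at the hydroxy-bearing carbon so far left this assay unchanged. A step of no more than the scatter is therefore expected, with no clear direction, giving a 1.1-fold lower number from compound 1 to compound 4 (0.03 log units; within the scatter). Compound 4 is estimated at 7.5 h, within 4 h to 14 h.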

Compound 4, half-life: < 3 h
Compound 4: a limit, no number; the forecaster's own chance of this, stated with the estimate: 0%; middle value at least 2.5-fold (0.39 log units) from the limit.
By their numbers in this assay, from the lowest: compounds 3, 2 and 1 (each within the scatter of the next). At a limit, below all of these: compound 4.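

In this assay, the group on this saturated ring carbon can matter: changes at the hydroxy-bearing carbon among compound 1, compound 2 and compound 3 stayed within the scatter, whereas acetamidomethyl in place of 1-hydroxyethyl gives an at least 2.7-fold lower number from compound 1 to compound 4 (0.43 log units; beyond the scatter). Compound 4 stands only as a limit: the limit of < 3 h in this assay, at which 1 of the 4 values shown sits.

The true size of this step stays open, and the compounds shown do not separate the amide from the longer chain. An aminomethyl or a hydroxymethyl group on this ring carbon would bear on that question.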